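The source may hold more compounds than are shown below. What is called first, only, known or untested is meant among the compounds shown, and "the series" means these compounds.

Compound 2, with the structure `O=c1cc(N2CCN(CC3CCC(OS(=O)(=O)c4cccnc4)CC3)CC2)sc2c([N+](=O)[O-])cc(C(F)(F)F)cc12`, stands at the edge of what the measurement can report: in an ADME assay on Vero cells (Chlorocebus sabaeus) for cytotoxicity, read by MTT assay, with a stated time of 48 h (a higher number here means a weaker inhibitor, a lower number a stronger inhibitor), compound 2 gives > 64 ug/mL, which is a limit of the assay rather than a number. Among the compounds with values here, compound 1, with the structure `O=C(OC1CCC(CN2CCN(c3cc(=O)c4cc(C(F)(F)F)cc([N+](=O)[O-])c4s3)CC2)CC1)C1CCCCC1`, is the only other compound measured here; in this assay compound 1 likewise gives > 64 ug/mL, again a limit. Within the data shown here, the single step between them, a step that the two limits leave unreadable from compound 1 to compound 2, cannot be read because both ends sit at the limit, as the limit of > 64 ug/mL in this assay, at which 2 of the 2 values shown sit, records.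

Compound 3, with the structure `O=C(OC1CCC(CN2CCN(c3cc(=O)c4cc(C(F)(F)F)cc([N+](=O)[O-])c4s3)CC2)CC1)c1cccc(F)c1`, differs from compound 2 by (3-fluorophenyl)carbonyl in place of (pyridin-3-yl)sulfonyl on an oxygen on a saturated carbon. Among the measured compounds shown here, no measured step bears on this change, since the one step available is unreadable. Compound 3 is therefore expected to give 64 ug/mL in this assay, with a likely range from 32 ug/mL to 128 ug/mL. The expected step of a number no higher from compound 2 to compound 3 (the limit leaves the size open) is estimated to lie within the scatter, and most probably compound 3 is expected to return only a limit as well.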

Compound 3, half-maximal inhibitory concentration: > 64 ug/mL
Compound 3 was reported as a limit; the forecaster's own chance of this, stated with the estimate: 75%; the middle value lies on the limit itself.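

The steps from compound 2 to compound 3 and from compound 1 to compound 3 cannot be read, because all three compounds sit at the same edge of the measurement: the limit of > 64 ug/mL in this assay, at which 3 of the 3 values shown sit.

The compounds shown leave open how far each lies beyond that limit in this assay, and whether these changes alter the read-out at all.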